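From tert-butoxy to benzylamino on a carbonyl carbon

A few compounds are considered here, and "the series" means these few. Any claim that something is new, unique, unknown or untested is made for them only; others in the source may bear on it.

In a physicochemical assay for solubility, in phosphate buffer, at pH 6.5 (a higher number here means a more soluble compound, a lower number a less soluble compound), compound 1 `C=C[C@@H]1C[C@]1(NC(=O)[C@@H]1C[C@@H](Oc2nccc3cc(OC)ccc23)CN1C(=O)[C@@H](NC(=O)N[C@@H](CC)COC)C(C)(C)C)C(=O)NS(=O)(=O)C1CC1` gives 500 ug/mL. Compound 2 `C=C[C@@H]1C[C@]1(NC(=O)[C@@H]1C[C@@H](Oc2nccc3cc(OC)ccc23)CN1C(=O)[C@@H](NC(=O)N[C@H](C(=O)OC(C)(C)C)C(C)(C)C)C(C)(C)C)C(=O)NS(=O)(=O)C1CC1` gives 1 ug/mL, the lower of the two numbers, and the gap is a 500-fold lower number from compound 1 to compound 2 (2.70 log units; beyond the scatter). Compound 3 `C=C[C@@H]1C[C@]1(NC(=O)[C@@H]1C[C@@H](Oc2nccc3cc(OC)ccc23)CN1C(=O)[C@@H](NC(=O)N[C@H](C(=O)NCc1ccccc1)C(C)(C)C)C(C)(C)C)C(=O)NS(=O)(=O)C1CC1` has not yet been measured. It carries benzylamino in place of tert-butoxy on a carbonyl carbon. Within the data shown here, only that one measured step bears on this change, and only indirectly, since it replaced 1-(methoxymethyl)propyl with a whole 2,2-dimethyl-1-(tert-butoxycarbonyl)propyl group. Among the measured compounds shown here, no measured pair isolates the exchange of tert-butoxy for benzylamino. Compound 3 keeps much of the group that entered in compound 2, so it is unlikely to regain most of the distance shown by a 500-fold lower number from compound 1 to compound 2 (2.70 log units; beyond the scatter). A small rise is therefore expected in this assay, estimated as a 3.0-fold higher number from compound 2 to compound 3 (0.48 log units; beyond the scatter). Compound 3 is expected at 3 ug/mL, within an estimated range of 0.7 ug/mL to 20 ug/mL.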

Compound 3, solubility: 95 ug/mL
The estimate for compound 3 lay 32-fold (1.50 log units) below the measured number; measured number above the stated range.
By their numbers in this assay, from the lowest: compound 2; then compound 3; then compound 1.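

In this assay, the exchange of tert-butoxy for benzylamino on a carbonyl carbon gives a 95-fold higher number from compound 2 to compound 3 (1.98 log units; beyond the scatter) with the rest of the structure unchanged. The earlier step had replaced the whole 2,2-dimethyl-1-(tert-butoxycarbonyl)propyl group, so it could not show what this outer part contributes; the low number of compound 2 at 1 ug/mL now proves not to be fixed by the remaining carbonyl and its saturated chain carbon, which compound 3 retains. No measurement shown accounts for the size of this step.

Going by these compounds, the aromatic ring and the nitrogen with its hydrogen enter together, so their separate shares remain open. Methylamino on the same carbonyl carbon would keep that nitrogen without the ring, and a carboxylic acid there would test a different kind of group.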